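The source may hold more compounds than are shown below. What is called first, only, known or untested is meant among the compounds shown, and "the series" means these compounds.

Compound 3 `C=CC(=O)Nc1ccc(Cn2nc(-c3ccc(Oc4ccccc4)cc3)cc2C(=O)OCC)cc1` is measured in a functional assay on JeKo-1 cells (Homo sapiens) for inhibition, read by luminescence and CellTiter-Glo, with a stated time of 72 h (on this read-out higher numbers stand for weaker inhibition and lower numbers for stronger inhibition), where compound 3 gives 10900 nM. This is the higher of the two numbers recorded: compound 1 `O=C(CCl)N1CCCC(n2nc(-c3ccc(Oc4ccccc4)cc3)cc2CO)C1` gives 7800 nM in this assay, and the two lie within the usual scatter of each other. Compound 2 `C=CC(=O)Nc1ccc(Cn2nc(-c3ccc(Oc4ccccc4)cc3)cc2C(=O)O)cc1` reaches only a limit of the assay, > 60000 nM in this assay. Going by the values given here, the single measured step, an at least 5.5-fold lower number from compound 2 to compound 3 (0.74 log units; beyond the scatter), rests on the limit of > 60000 nM in this assay, at which 1 of the 3 values shown sits, and concerns the ethyl on the oxygen next to the carbonyl, not the ring carrying the acrylamide. Compound 4 `C=CC(=O)Nc1cccc(Cn2nc(-c3ccc(Oc4ccccc4)cc3)cc2C(=O)OCC)c1` differs from compound 3 by 3-((vinylcarbonyl)amino)phenyl in place of 4-((vinylcarbonyl)amino)phenyl on a saturated chain carbon bound to an aromatic nitrogen. Among the compounds with values here, no measured step covers this change, so in this assay compound 4 is expected to stay within the scatter of compound 3, an estimated step of a 1.0-fold higher number from compound 3 to compound 4 (0.00 log units; within the scatter). The estimate for compound 4 is 11000 nM, with a range from 3500 nM to 35000 nM.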

Compound 4, half-maximal inhibitory concentration: 7600 nM
Compound 4: the middle estimate sits 1.4-fold (0.16 log units) above what was measured; low and high end bracket the measured number.
By their numbers in this assay, from the lowest: compounds 4, 1 and 3 (each within the scatter of the next). At a limit, above all of these: compound 2.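

Going by these compounds alone, with 3-((vinylcarbonyl)amino)phenyl in place of 4-((vinylcarbonyl)amino)phenyl on a saturated chain carbon bound to an aromatic nitrogen, this assay shows a 1.4-fold lower number from compound 3 to compound 4 (0.16 log units; within the scatter) as the first reading at this position. Within the data shown here, the earlier step concerned only the ethyl, so this is the first sign that the change of attachment leaves the number within the scatter. Nothing at hand bears on why.

The compounds shown leave open whether a longer chain in place of the ethyl would change the number. They also leave open whether a propanamide in place of the vinylcarbonyl amide would do so.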